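A few compounds are considered here, and "the series" means these few. Any claim that something is new, unique, unknown or untested is made for them only; others in the source may bear on it.

Measured in a functional assay on brain (Rattus norvegicus, strain Wistar) for inhibition; on this read-out higher numbers stand for weaker inhibition and lower numbers for stronger inhibition:
- compound 1 `CCCc1ccc(-c2c(C)[nH]c(=O)n2C)cc1` gives 21500 nM
- compound 2 `CCCCCCCc1ccc(-c2c(C)[nH]c(=O)n2C)cc1` gives 8400 nM
- compound 3 `CCCCCCCCc1ccc(-c2c(C)[nH]c(=O)n2C)cc1` gives 19400 nM

Going by the values given here, compound 3 stands at the upper end of the numbers so far. The series shows a 1.1-fold lower number from compound 1 to compound 3 (0.04 log units; within the scatter), and also a 2.3-fold higher number from compound 2 to compound 3 (0.36 log units; beyond the scatter).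

The next structure is compound 4 `CCCCCCCCCCc1ccc(-c2c(C)[nH]c(=O)n2C)cc1`, and the change is ethyl in place of hydrogen on a saturated chain carbon, eight bonds along the chain from an aromatic carbon. Among the compounds with values here, the closest precedent is the last chain extension, a 2.3-fold higher number from compound 2 to compound 3 (0.36 log units; beyond the scatter), a modest move towards weaker inhibition. The earlier 2.6-fold lower number from compound 1 to compound 2 (0.41 log units; beyond the scatter) goes against that direction, so chain length does not move the number one way throughout. With only these steps to go on, a modest rise in the number in this assay is expected, with little confidence that it will clear the scatter. The expected change is a 1.4-fold higher number from compound 3 to compound 4 (0.16 log units; within the scatter). Compound 4 is estimated at 28000 nM, with an expected range from 11000 nM to 70000 nM.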

Compound 4, half-maximal inhibitory concentration: 7900 nM
The estimate for compound 4 lay 3.5-fold (0.55 log units) above the measured number; measured number outside the range, below it.
By their numbers in this assay, from the lowest: compounds 4 and 2 (each within the scatter of the next); then compounds 3 and 1 (each within the scatter of the next).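

In this assay the ethyl extension, eight bonds along the chain from an aromatic carbon, turns the number back down, with a 2.5-fold lower number from compound 3 to compound 4 (0.39 log units; beyond the scatter) reversing the rise seen at the previous extension. Compound 4 is not separated from compound 2 (a 1.1-fold lower number from compound 2 to compound 4 (0.03 log units; within the scatter)) and keeps a modest gain over the shortest chain (a 2.7-fold lower number from compound 1 to compound 4 (0.43 log units; beyond the scatter)), so lengthening the chain past compound 3 does not carry inhibition further away. Chain length therefore gives no steady trend across the four compounds: compounds 2 and 4 lie together, compounds 1 and 3 lie together, and compound 3 breaks any smooth curve.

From the compounds shown here alone, whether the up-and-down continues with a longer chain, or how an amine or a carboxylic acid in place of the chain would read, stays open. Nothing at hand accounts for this alternation.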